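Swapping Methoxy for Methyl: Expected Effect on Half-Life

A few compounds are considered here, and "the series" means these few. Any claim that something is new, unique, unknown or untested is made for them only; others in the source may bear on it.

Measured compounds:
- Compound 1, `COc1cnc(C[S+]([O-])c2nc3cc(OC(F)(F)C(F)F)ccc3[nH]2)cc1OC`: 2.9 h
- Compound 2, `COc1cc(C[S+]([O-])c2nc3cc(OC(F)(F)C(F)F)ccc3[nH]2)ncc1C`: 0.2 h
- Compound 3, `COc1cc2[nH]c([S+]([O-])Cc3nccc(OC)c3OC)nc2cc1OC(F)F`: 2.1 h

All three were tested in an ADME assay, at pH 5; a lower number here means that the compound disappears faster, a higher number that the compound lasts longer. Compound 1 gives 2.9 h, and compound 3 gives 2.1 h; the gap between them is within the usual scatter, so the two cannot be ranked against each other. Compound 2 stands apart with 0.2 h.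

Compounds 1 and 2 differ in one place only: methyl in place of methoxy on an aromatic carbon. That single change produced a 15-fold lower number from compound 1 to compound 2 (1.16 log units; beyond the scatter). How the core of compound 3 differs from the core of compound 1 is not broken down here.

Compound 4, `COc1cc2[nH]c([S+]([O-])Cc3nccc(OC)c3C)nc2cc1OC(F)F`, has not yet been measured. It is made from compound 3 by the same kind of change: methyl in place of methoxy on an aromatic carbon. The surroundings are not identical, though: in compound 1 the place is para to a large group, whereas in compound 3 it is ortho to a large group.

For the measured compounds named here, because the only precedent is a 15-fold lower number from compound 1 to compound 2 (1.16 log units; beyond the scatter), a drop of similar size is expected from compound 3, giving an estimated 11-fold lower number from compound 3 to compound 4 (1.02 log units; beyond the scatter) in this assay. Compound 4 is therefore expected to reach roughly 0.2 h, plausibly between 0.07 h and 0.6 h, with the wider range reflecting that the change sits in a different surrounding than it did between compound 1 and compound 2.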

Compound 4, half-life: 0.2 h
Beside the measured number, compound 4's estimate shows no gap at the digits printed; the measured number falls inside the stated range.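

In this assay, putting methyl in place of methoxy on an aromatic carbon gives an 11-fold lower number from compound 3 to compound 4 (1.02 log units; beyond the scatter), and this step closely matches the one seen earlier on a different core: the same change on two cores in this assay, a 15-fold lower number (1.16 log units; beyond the scatter) from compound 1 to compound 2 and an 11-fold lower number (1.02 log units; beyond the scatter) from compound 3 to compound 4, 1.4-fold (0.14 log units) apart, within the scatter of two such steps

Within these two pairs, then, the change carries over from the core of compound 1 to the core of compound 3 with much the same size, even though in compound 4 the methyl sits ortho to a large group and ortho to a methoxy group, a different surrounding from the one in compound 2. Two pairs are still a small sample: they do not show that the step would hold on every core in this series, and they do not explain why the half-life falls so sharply.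

The compounds shown leave open how other groups at this place would behave, for example a plain hydrogen, a chlorine atom, an ethyl chain or an amine, and so whether the short half-life goes with the arrival of methyl or simply with the loss of methoxy. They also leave open whether the same swap elsewhere on the aromatic ring would produce a step of similar size.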